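One more ring swap in a level series

The source may report more compounds than this note shows. Statements on the series, on what has been measured and on what is new or still open speak of the compounds shown alone.

In a functional assay on A2780 cells (Homo sapiens) for inhibition (on this read-out higher numbers stand for weaker inhibition and lower numbers for stronger inhibition), three compounds have been measured. Compound 1 (`CC(C(=O)Nc1cc(C2CC2)[nH]n1)c1ccc(N2C(=O)CCC2C)cc1`) gives 6400 nM, compound 2 (`CC(C(=O)Nc1cc(C2CC2)[nH]n1)c1ccc(N2CCC(C(N)=O)C2=O)cc1`) gives 5710 nM, and compound 3 (`CC(C(=O)Nc1cc(C2CC2)[nH]n1)c1ccc(-n2ccnc2O)cc1`) gives 6980 nM. Compound 3 therefore stands level with the other two, within the usual scatter of both. Compound 4 (`CC(C(=O)Nc1cc(C2CC2)[nH]n1)c1ccc(N2CCCS2(=O)=O)cc1`), not yet measured, keeps the shared core and differs from compound 3 in one group: a group of 7 heavy atoms (3 carbon, 1 nitrogen, 2 oxygen, 1 sulfur; one five-membered non-aromatic ring with 2 hetero atoms) in place of a group of 6 heavy atoms (3 carbon, 2 nitrogen, 1 oxygen; one five-membered aromatic ring with 2 hetero atoms), on an aromatic carbon. The change lies on an aromatic carbon of a six-membered aromatic ring of carbon only, para to a large group. Three measured steps at this place bear on it: a 1.1-fold lower number from compound 1 to compound 2 (0.05 log units; within the scatter), a 1.1-fold higher number from compound 1 to compound 3 (0.04 log units; within the scatter) and a 1.2-fold higher number from compound 2 to compound 3 (0.09 log units; within the scatter). All three stay within the scatter, although the groups exchanged differ in size and ring type. Among the measured compounds shown here, no measured compound carries sulfur, so the new group remains untested. No change beyond the scatter is expected, and the expected step is a 1.2-fold lower number from compound 3 to compound 4 (0.07 log units; within the scatter). In this assay the estimate for compound 4 is 6000 nM, with an expected range from 2500 nM to 15000 nM.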

Compound 4, half-maximal inhibitory concentration: 5240 nM
The estimate for compound 4 lay 1.1-fold (0.06 log units) above the measured number; low and high end bracket the measured number.
By their numbers in this assay, from the lowest: compounds 4, 2, 1 and 3 (each within the scatter of the next).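

In this assay the sulfur-bearing ring joins the level series: a 1.3-fold lower number from compound 3 to compound 4 (0.12 log units; within the scatter) and a 1.1-fold lower number from compound 2 to compound 4 (0.04 log units; within the scatter) and a 1.2-fold lower number from compound 1 to compound 4 (0.09 log units; within the scatter) all lie within the scatter. This position, on an aromatic carbon para to a large group, thus shows no measurable response to a first group holding sulfur and 2 double bonds outside aromatic rings, nor to the exchange of 1 hydrogen-bond donor in compound 3 for 0 hydrogen-bond donors in compound 4. No measured finding accounts for this levelness.

From the compounds shown here alone, all four compounds carry a five-membered ring at this place, so it stays open whether a simple amine, a carboxylic acid or an open alkyl chain would leave the number level. Going by these compounds, it also stays open whether any group here can move the number beyond the scatter.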